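A few compounds are considered here, and "the series" means these few. Any claim that something is new, unique, unknown or untested is made for them only; others in the source may bear on it.

Measured compounds:
compound 1 `CN(C(=O)NC(=O)c1cccc(C(F)(F)F)c1)c1nc(C(F)(F)F)c(C(=O)N/N=C/c2ccccc2C(F)(F)F)s1`: 12.1 ug/mL
compound 2 `Cc1nc(N(C)C(=O)NC(=O)c2c(F)cccc2F)sc1C(=O)N/N=C/c1ccccc1C(F)(F)F`: 5.43 ug/mL

Two compounds have been run in a functional assay on A549 cells (Homo sapiens) for inhibition, read by MTT assay, with a stated time of 72 h; on this read-out higher numbers stand for weaker inhibition and lower numbers for stronger inhibition. Compound 1 gives 12.1 ug/mL and compound 2 gives 5.43 ug/mL. Among the measured compounds shown here, compound 2 thus stands with the lowest of the two numbers, and the only other number, that of compound 1, is higher by a margin that lies beyond the scatter. Compound 1 and compound 2 differ from each other in more than one place, so their two values are simply shown side by side and no single step is drawn between them.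

Compound 3 `CN(C(=O)NC(=O)c1c(F)cccc1F)c1nc(C(F)(F)F)c(C(=O)N/N=C/c2ccccc2C(F)(F)F)s1` has not yet been measured in this assay. It differs from compound 2 in one place: trifluoromethyl in place of methyl on an aromatic carbon. For the measured compounds named here, no step between measured compounds isolates this change, so there is no measured step to lean on. The expectation is a small step, if any, toward a higher number, and it may well fall within the scatter, so the step from compound 2 to compound 3 is estimated as a 1.3-fold higher number from compound 2 to compound 3 (0.11 log units; within the scatter). For compound 3 the estimate is 7 ug/mL, with a range from 3 ug/mL to 16 ug/mL.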

Compound 3, half-maximal inhibitory concentration: 17.9 ug/mL
Beside the measured number, compound 3's estimate is 2.6-fold (0.41 log units) below it, outside the stated range (above it).
By their numbers in this assay, from the lowest: compound 2; then compounds 1 and 3 (each within the scatter of the next).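

In this assay the aromatic carbon next to the ring nitrogen now has a measured step: trifluoromethyl in place of methyl gives a 3.3-fold higher number from compound 2 to compound 3 (0.52 log units; beyond the scatter) and so moves toward weaker inhibition, which shows that, with the 2,6-difluorophenyl group held fixed, this position is not indifferent to the change. The other single change, 2,6-difluorophenyl in place of 3-(trifluoromethyl)phenyl on a carbonyl carbon, gives a 1.5-fold higher number from compound 1 to compound 3 (0.17 log units; within the scatter) with trifluoromethyl held on the ring, so with that group in place this assay does not tell these two groups apart. Nothing measured here offers an explanation for the step at the ring carbon.

Whether methyl would also read differently from trifluoromethyl with the 3-(trifluoromethyl)phenyl group on the carbonyl carbon remains open, since the compounds shown test that swap only with the 2,6-difluorophenyl group. Also open, on these data alone, is how an ethyl group, a chlorine atom or an amine on the same ring carbon would read, and so whether the step follows the size of the group or something specific to its fluorine atoms.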